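One Methoxymethyl Addition Carried Over to a Charged Analogue

The source may report more compounds than this note shows. Statements on the series, on what has been measured and on what is new or still open speak of the compounds shown alone.

Compound 1 `CCN1CCc2c(sc(NC(=O)Nc3ccc(Cl)cc3)c2C(N)=O)C1`: 3120 nM
Compound 2 `COCCCN1CCc2c(sc(NC(=O)Nc3ccc(Cl)cc3)c2C(N)=O)C1`: 2400 nM
Compound 3 `CC[N+]1(C)CCc2c(sc(NC(=O)Nc3ccc(Cl)cc3)c2C(N)=O)C1`: 1960 nM

In a functional assay (strain AB) with Danio rerio as the target, read by microscopy, with a stated time of 1 h (on this read-out lower numbers stand for an effect already at smaller amounts and higher numbers for an effect only at larger amounts of compound), compound 1 gives 3120 nM, while compound 2 gives 2400 nM. Compound 2 differs from compound 1 by methoxymethyl in place of hydrogen on a saturated chain carbon, two bonds along the chain from an amine nitrogen in a ring, and that change made a step of a 1.3-fold lower number from compound 1 to compound 2 (0.11 log units; within the scatter). Compound 3 gives 1960 nM in this assay; compound 3 and compound 1 differ in more than one place, and the difference between their two cores is not broken down here.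

Compound 4 `COCCC[N+]1(C)CCc2c(sc(NC(=O)Nc3ccc(Cl)cc3)c2C(N)=O)C1` is not yet measured. It differs from compound 3 by methoxymethyl in place of hydrogen on a saturated chain carbon, two bonds along the chain from an amine nitrogen in a ring, the same change as that from compound 1 to compound 2. Compound 4 is expected to show a step of a 1.3-fold lower number from compound 3 to compound 4 (0.12 log units; within the scatter) in this assay, an expectation that rests on the earlier step of a 1.3-fold lower number from compound 1 to compound 2 (0.11 log units; within the scatter) and on the value of compound 3, 1960 nM. Compound 4 is therefore estimated at 1500 nM, most likely between 700 nM and 3200 nM.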

Compound 4, half-maximal effective concentration: 480 nM
Compound 4: middle estimate off by 3.1-fold (0.49 log units), on the high side, outside the stated range (below it).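

In this assay, methoxymethyl in place of hydrogen made a step of a 4.1-fold lower number from compound 3 to compound 4 (0.61 log units; beyond the scatter), and this step does not match the one the same change made on the core of compound 1: the same change on two cores in this assay, a 1.3-fold lower number (0.11 log units; within the scatter) from compound 1 to compound 2 and a 4.1-fold lower number (0.61 log units; beyond the scatter) from compound 3 to compound 4, 3.1-fold (0.50 log units) apart, beyond the scatter of two such steps

The size of the step therefore did not carry over from one core to the other, so a step read on one core was a poor guide to the other in this series. With a single pair on each core, this does not show how the change would behave on any further core, and it gives no cause for the gap.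

As far as these compounds go, whether a longer chain, an alcohol or an amine in place of methoxymethyl would also step differently on the two cores remains open.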